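Cap replacement in hydroxamate series: furan-2-yl for dimethylaminophenyl

The source may report more compounds than this note shows. Statements on the series, on what has been measured and on what is new or still open speak of the compounds shown alone.

Two compounds of the series have numbers in a functional assay on MM96L cells (Homo sapiens) for antiproliferative activity; on this read-out higher numbers stand for weaker inhibition and lower numbers for stronger inhibition. Compound 1 `CN(C)c1ccc(C(=O)N[C@@H](CCCCCC(=O)NO)C(=O)NCc2ccccc2)cc1` gives 1600 nM in this assay. Compound 2 `CN(C)c1ccc(C(=O)NC(CCCCCC(=O)NO)C(=O)NCc2ccccc2)cc1` gives 130 nM in this assay and thus stands lowest of the two numbers, its nearest neighbour being compound 1. For the measured compounds named here, the only measured step is a 12-fold lower number from compound 1 to compound 2 (1.09 log units; beyond the scatter), which rests on the fact that one of compounds 1 and 2 is drawn with a defined configuration and the other without, at the place where they differ alone and is not a change of atoms or bonds.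

Compound 3 `O=C(CCCCCC(NC(=O)c1ccco1)C(=O)NCc1ccccc1)NO` differs from compound 2 in one place: furan-2-yl in place of 4-(dimethylamino)phenyl on a carbonyl carbon. Going by the values given here, the single measured step concerns a stereo drawing, not a change of the group on the carbonyl carbon, so it gives no direct guide to the size or direction of this step. With the cap shrunk from a six-membered carbocycle bearing a dimethylamino group to a five-membered heteroaromatic ring, the working expectation for compound 3 is a step of a 2.3-fold higher number from compound 2 to compound 3 (0.36 log units; beyond the scatter) in this assay, that is, a somewhat weaker inhibitor than compound 2, with wide uncertainty. Compound 3 is estimated at 300 nM, within a range of 70 nM to 1500 nM.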

Compound 3, half-maximal inhibitory concentration: 200 nM
Beside the measured number, compound 3's estimate is 1.5-fold (0.18 log units) above it, within the range that was stated.
By their numbers in this assay, from the lowest: compounds 2 and 3 (each within the scatter of the next); then compound 1.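

At the place on a carbonyl carbon whose other neighbour is an amide-type nitrogen, this assay gives a 1.5-fold higher number from compound 2 to compound 3 (0.19 log units; within the scatter), so furan-2-yl and 4-(dimethylamino)phenyl cannot be told apart on this read-out. For the compounds shown here, the earlier pair spoke only to how a stereocentre is drawn, whereas this step is the first reading of a change of atoms, and it shows that neither the dimethylamino group nor the six-membered aromatic ring of carbon is needed to keep the number within the scatter of that of compound 2, even with fewer heavy atoms in the group. Nothing measured here bears on why the two groups read alike.

The compounds shown leave open whether a group such as thiophen-2-yl, plain phenyl or cyclohexyl on the same carbonyl carbon would also stay within the scatter, and whether an amine or a carboxylic acid carried on the furan ring would move the number. They also leave open how the furan-2-yl compound reads with its stereocentre drawn S, since compound 3 carries no drawn configuration and the step seen with the 4-(dimethylamino)phenyl cap need not carry over.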